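A few compounds are considered here, and "the series" means these few. Any claim that something is new, unique, unknown or untested is made for them only; others in the source may bear on it.

Measured so far:
compound 1, `Oc1ccc(-c2cc(-c3cccc(Cl)c3)nc(-c3cccs3)c2)cc1`: 52.4%
compound 2, `Oc1ccc(-c2cc(-c3ccncc3)nc(-c3cccc(Cl)c3)c2)cc1`: 29.2%

In an assay on isolated protein for inhibition of DNA topoisomerase 1 (Homo sapiens), with a stated time of 30 min, tested at 100 uM (a lower number here means a weaker effect, a higher number a stronger effect of the compound at the concentration tested), compound 1 gives 52.4%, and compound 2 gives 29.2%. Within the data shown here, compound 2 thus stands at the lower of the two numbers, and the only measured step, a number 23.2 percentage points lower from compound 1 to compound 2 (beyond the scatter), is the one that leads to it: pyridin-4-yl in place of thiophen-2-yl on an aromatic carbon.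

Compound 3, `Oc1ccc(-c2cc(-c3ccccc3)nc(-c3cccc(Cl)c3)c2)cc1`, is not yet measured. It differs from compound 2 in one place: phenyl in place of pyridin-4-yl on an aromatic carbon. Among the measured compounds shown here, the ring that sits next to the ring nitrogen of the shared core is exchanged once more, and the only step that bears on this exchange is the one from compound 1 to compound 2, in which pyridin-4-yl entered at this very place and the number fell by a modest amount beyond the scatter. Here pyridin-4-yl leaves again, so a rise of roughly that order seems the most reasonable expectation, though phenyl is not thiophen-2-yl and the step in this assay could well be smaller. Compound 3 is therefore expected to give about 45%, within a range of 25% to 65%. This estimate means a step of a number 15.8 percentage points higher from compound 2 to compound 3 (beyond the scatter).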

Compound 3, a percentage reported as inhibition, at one concentration (the size of the read-out at that concentration, not a potency): 0%
Compound 3: middle estimate off by 45 percentage points, on the high side; measured number below the stated range.
By their numbers in this assay, from the lowest: compound 3; then compound 2; then compound 1.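

In this assay, among these compounds, the earlier compounds could suggest that pyridin-4-yl simply lowers the number at this place, but the new result shows otherwise: the change to phenyl gives a number 29.2 percentage points lower from compound 2 to compound 3 (beyond the scatter), and the change from thiophen-2-yl to phenyl gives a number 52.4 percentage points lower from compound 1 to compound 3 (beyond the scatter). The three groups therefore fall in the order phenyl, pyridin-4-yl, thiophen-2-yl from lowest to highest, and each gap lies beyond the scatter. Swapping the ring nitrogen of pyridin-4-yl for carbon is enough to produce a clear change, even though both groups are six-membered aromatic rings, but no measurement here explains why these groups differ.

These three compounds cannot show whether the nitrogen itself or its location within the ring matters, and pyridin-3-yl or pyridin-2-yl at this place would separate those two possibilities. Nor can they show whether sulfur is what sets thiophen-2-yl apart, a question that furan-2-yl or thiophen-3-yl would help to answer.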